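Changing the aryl group on the ring nitrogen

The source may report more compounds than this note shows. Statements on the series, on what has been measured and on what is new or still open speak of the compounds shown alone.

Of the compounds shown here, three built on a shared core have been measured in a functional assay on HCT-116 cells (Homo sapiens) for inhibition, read by MTT assay, with a stated time of 72 h; a lower number here means a stronger inhibitor, a higher number a weaker inhibitor. Compound 1 `O=C1Nc2ccccc2/C1=N/NC(=S)N1CCN(c2ccccc2)CC1` gives 11100 nM. Compound 2 `O=C1Nc2ccc(Br)cc2/C1=N/NC(=S)N1CCN(c2ccccc2)CC1` carries bromo in place of hydrogen on an aromatic carbon and gives 10400 nM; the step of a 1.1-fold lower number from compound 1 to compound 2 (0.03 log units; within the scatter) shows that this change made no difference that can be trusted. Compound 3 `Cc1ccc(N2CCN(C(=S)N/N=C3\C(=O)Nc4ccc(Cl)cc43)CC2)c(C)c1` gives 7180 nM in this assay. For the measured compounds named here, on the numbers so far it is the lowest of the three, but its gaps to compound 2 and to compound 1 both lie within the scatter, so nothing separates these three compounds.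

Compound 4 `O=C1Nc2ccc(Cl)cc2/C1=N/NC(=S)N1CCN(c2ccc([N+](=O)[O-])cc2)CC1` keeps the chloro-bearing core of compound 3 and differs in one place: 4-nitrophenyl in place of 2,4-dimethylphenyl on an amine nitrogen in a ring. Going by the values given here, no measured step touches this part of the molecule; the only step known concerns the core and was itself within the scatter. With nothing to point either way, compound 4 is expected to show a step of a 1.0-fold higher number from compound 3 to compound 4 (0.02 log units; within the scatter) that stays within the scatter. Compound 4 is therefore estimated at 7500 nM, with a range from 3000 nM to 20000 nM.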

Compound 4, half-maximal inhibitory concentration: 12000 nM
Compound 4: the middle estimate sits 1.6-fold (0.20 log units) below what was measured; the range from low to high includes it.
By their numbers in this assay, from the lowest: compounds 3, 2, 1 and 4 (each within the scatter of the next).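

For the compounds shown here, this step is the first measured change to the aryl group on the ring nitrogen, and in this assay it gives a 1.7-fold higher number from compound 3 to compound 4 (0.22 log units; within the scatter) without going beyond what repeat measurements would produce. The two groups share a six-membered aromatic ring of carbon only and differ in what that ring carries, yet exchanging 2,4-dimethylphenyl for 4-nitrophenyl produces no difference that can be trusted at this position. No supporting measurement bears on this result.

On these data alone, both groups are substituted phenyl rings, so it remains open whether a group of another kind on this amine nitrogen, such as a benzyl group or a simple alkyl chain, would move the number beyond the scatter. As far as these compounds go, it is also open whether a carboxylic acid or an amine carried on the phenyl ring would do so.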